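The source may report more compounds than this note shows. Statements on the series, on what has been measured and on what is new or still open speak of the compounds shown alone.

The measured compounds, each with its result in a functional assay on A-431 cells (Homo sapiens) for cytotoxicity, read by MTT assay, with a stated time of 72 h, tested at 1 uM; a higher number here means more inhibition of growth at the concentration tested, a lower number less inhibition of growth:
compound 1 `N/C(=N\NC(=S)N1CCCCCC1)c1ccccn1` gives 18.8%;
compound 3 `N/C(=N\NC(=S)N1CCSCC1)c1ccccn1` gives 31.7%;
compound 2 `Cc1cccc(/C(N)=N/NC(=S)N2CCSCC2)n1` gives 42.8%.

Compound 1 stands lowest of the three in this assay, with both other compounds beyond the scatter above it. Compound 3 and compound 2 share one core and differ only by methyl in place of hydrogen on an aromatic carbon, a change that produced a number 11.1 percentage points higher from compound 3 to compound 2 (beyond the scatter). Compound 4 `Cc1cccc(/C(N)=N/NC(=S)N2CCCCCC2)n1` is built from compound 1 by the same change, (methyl in place of hydrogen on an aromatic carbon). The difference between the core of compound 1 and the core of compound 3 is not broken down here. For compound 4 a step like a number 11.2 percentage points higher from compound 1 to compound 4 (beyond the scatter) is expected, and that expectation rests on the step seen in compound 2, a number 11.1 percentage points higher from compound 3 to compound 2 (beyond the scatter). Compound 4 is therefore estimated at 30% in this assay, most likely within 16% to 44%.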

Compound 4, percent growth inhibition at one concentration: 42.8%
The estimate for compound 4 lay 12.8 percentage points below the measured number; the range from low to high includes it.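

In this assay methyl in place of hydrogen on an aromatic carbon gave a number 24 percentage points higher from compound 1 to compound 4 (beyond the scatter), so the number rose on both cores shown. The two steps go the same way and cannot be told apart in size: the same change on two cores in this assay, a number 11.1 percentage points higher (beyond the scatter) from compound 3 to compound 2 and a number 24 percentage points higher (beyond the scatter) from compound 1 to compound 4, 12.9 percentage points apart, within the scatter of two such steps. This supports carrying the change between these two cores in this assay, but two pairs do not show that it would carry to any other core in the series.

The compounds shown carry only hydrogen or methyl at this place on the ring. They leave open whether an ethyl group, a methoxy group or a chlorine atom there would move the number the same way.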